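This account rests on a few compounds, and the source may have more. Where it says the series, first, only, none or still open, it means among the compounds named here.

Measured so far in a functional assay (ileum) for antagonist activity, with Cavia porcellus as the target; on this read-out lower numbers stand for stronger inhibition and higher numbers for weaker inhibition:
- compound 1 `CC1=C(C(=O)O[C@H](C)CO[N+](=O)[O-])[C@H](c2cccc3nonc23)C([N+](=O)[O-])=C(C)C1` gives 36500 nM
- compound 2 `CC1=C(C(=O)O[C@@H](C)CO[N+](=O)[O-])[C@H](c2cccc3nonc23)C([N+](=O)[O-])=C(C)C1` gives 9430 nM
- compound 3 `CC1=C(C(=O)OC(C)CO[N+](=O)[O-])C(c2cccc3nonc23)C([N+](=O)[O-])=C(C)C1` gives 6380 nM

Compound 3 has the lowest number of the three, but its gap to compound 2 sits within the scatter a 1.5-fold lower number from compound 2 to compound 3 (0.17 log units; within the scatter); only one gap is clear, a 5.7-fold lower number from compound 1 to compound 3 (0.76 log units; beyond the scatter).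

The step to compound 4 `CC1=C(C(=O)O[C@@H](C)CO[N+](=O)[O-])[C@@H](c2cccc3nonc23)C([N+](=O)[O-])=C(C)C1` is the two compounds have the same atoms and bonds; at least one stereo element is drawn with a configuration in one of them and without one in the other: 2 of 2 stereo elements differ; a stereocentre at a saturated chain carbon is drawn without a configuration in compound 3 and S in compound 4; a stereocentre at a saturated ring carbon is drawn without a configuration in compound 3 and R in compound 4. Among the compounds with values here, three measured steps bear on it. Within the pair with defined configuration, the chain stereocentre alone moves the number a 3.9-fold lower number from compound 1 to compound 2 (0.59 log units; beyond the scatter), which rests on (the fact that compounds 1 and 2 differ only in the configuration as drawn). Against the compound without drawn configuration, compound 1 stands clearly higher a 5.7-fold lower number from compound 1 to compound 3 (0.76 log units; beyond the scatter), resting on (the fact that one of compounds 1 and 3 is drawn with a defined configuration and the other without, at the place where they differ), while compound 2 does not differ beyond scatter a 1.5-fold lower number from compound 2 to compound 3 (0.17 log units; within the scatter), resting on (the fact that one of compounds 2 and 3 is drawn with a defined configuration and the other without, at the place where they differ). Compound 3 carries no drawn configuration at either centre and still gives the lowest number of the set, so the ring configuration not yet measured is expected to carry a lower number. Compound 4 shares the chain configuration of compound 2 and adds the other ring configuration; a modest step downward in this assay is expected, a 2.1-fold lower number from compound 3 to compound 4 (0.33 log units; beyond the scatter). Compound 4 is therefore estimated at 3000 nM, within 1000 nM to 9000 nM.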

Compound 4, half-maximal inhibitory concentration: 577 nM
Estimate against measurement, compound 4: 5.2-fold (0.72 log units) above; the measured number lies below the stated range.
By their numbers in this assay, from the lowest: compound 4; then compounds 3 and 2 (each within the scatter of the next); then compound 1.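

The ring stereocentre emerges as the main stereochemical handle here: with the chain stereocentre held at S in this assay, changing the ring stereocentre from S to R gives a 16-fold lower number from compound 2 to compound 4 (1.21 log units; beyond the scatter), a large step, whereas the chain inversion gave only a modest one: the fact that compounds 2 and 4 differ only in the configuration as drawn. The two mirror images are far apart, with a 63-fold lower number from compound 1 to compound 4 (1.80 log units; beyond the scatter), so the configuration drawn in compound 4 is clearly favoured over its mirror image: the fact that compounds 1 and 4 differ only in the configuration as drawn. Compound 3 also stands well apart from the defined R ring, S chain form, with an 11-fold lower number from compound 3 to compound 4 (1.04 log units; beyond the scatter): the fact that one of compounds 3 and 4 is drawn with a defined configuration and the other without, at the place where they differ.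

The shown compounds leave open how the R ring configuration behaves with the chain drawn R, so the chain effect is read only with the ring drawn S. Also open is whether the preference for the R ring survives with a longer chain as the ester group.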